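This account rests on a few compounds, and the source may have more. Where it says the series, first, only, none or still open, it means among the compounds named here.

Measured so far:
- compound 1 `Cc1cc(Br)c(S(C)(=O)=O)cc1C(=O)N=C(N)N`: 12 nM in a functional assay for inhibition of sodium/hydrogen exchanger (Oryctolagus cuniculus); a lower number here means a stronger inhibitor, a higher number a weaker inhibitor
- compound 2 `CS(=O)(=O)c1cc(C(=O)N=C(N)N)ccc1-n1cccn1`: 160 nM in this assay
- compound 3 `CS(=O)(=O)c1cc(C(=O)N=C(N)N)ccc1Oc1cccnc1`: 76 nM in this assay

Compound 3 stands second highest of the three numbers; its nearest neighbour is compound 2, the furthest compound 1. Among the compounds with values here, the single step measured in one place, a 2.1-fold lower number from compound 2 to compound 3 (0.32 log units; beyond the scatter), is modest. Compound 4 `CS(=O)(=O)c1cc(C(=O)N=C(N)N)ccc1Br` differs from compound 3 by bromo in place of (pyridin-3-yl)oxy on an aromatic carbon. Within the data shown here, no measured step exchanges a pyridinyloxy for a bromo, so the bearing is indirect: compound 1, which carries the same bromo but an additional methyl, gives 12 nM. A downward step beyond the scatter in this assay is therefore expected for compound 4, though a smaller one than the gap separating compound 3 from compound 1. Compound 4 is expected at 22 nM with a range of 7 nM to 70 nM. The expected change is a 3.5-fold lower number from compound 3 to compound 4 (0.54 log units; beyond the scatter).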

Compound 4, half-maximal inhibitory concentration: 180 nM
Compound 4: the middle estimate sits 8.2-fold (0.91 log units) below what was measured; the measured number lies above the stated range.
By their numbers in this assay, from the lowest: compound 1; then compound 3; then compounds 2 and 4 (each within the scatter of the next).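

In this assay at the place ortho to a methylsulfonyl group, bromo brings no gain over (pyridin-3-yl)oxy (a 2.4-fold higher number from compound 3 to compound 4 (0.37 log units; beyond the scatter)), and it cannot be told apart from 1H-pyrazol-1-yl (a 1.1-fold higher number from compound 2 to compound 4 (0.05 log units; within the scatter)). The low number of compound 1 therefore does not come with bromo alone, since the large step goes with hydrogen in place of methyl (a 15-fold higher number from compound 1 to compound 4 (1.18 log units; beyond the scatter)). No measurement at hand accounts for these steps.

On these data alone, whether the same methyl would lower the number of compound 2 or compound 3 stays open. So does how an amine or a methoxy group would compare at the bromo place.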